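The source may hold more compounds than are shown below. What is called first, only, known or untested is meant among the compounds shown, and "the series" means these compounds.

Measured in a functional assay on MCF7 cells (Homo sapiens) for antiproliferative activity, read by MTT assay, with a stated time of 72 h; a higher number here means a weaker inhibitor, a lower number a stronger inhibitor:
- compound 1 `CCCC(=O)NNC(=O)c1csc2ncc(-c3ccc(C)cc3)n12`: 41700 nM
- compound 2 `CC(=O)NNC(=O)c1csc2ncc(-c3ccc(Br)cc3)n12`: 1830 nM

Of these two, compound 2 has the lower number and so stands as the stronger inhibitor, with a gap to compound 1 that lies beyond the scatter. The two compounds differ in more than one place, so that gap cannot be assigned to any single change.

Compound 3 `CCCC(=O)NNC(=O)c1csc2ncc(-c3ccc(Br)cc3)n12` departs from compound 2 in one place only: ethyl in place of hydrogen on a saturated chain carbon bound to a carbonyl carbon. This is ethyl in place of hydrogen on a saturated chain carbon bound to a carbonyl carbon, which turns acetyl into propylcarbonyl.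

Going by the values given here, no measured pair shows this change alone, so the evidence is indirect. Among the compounds with values here, the only compound measured with propylcarbonyl is compound 1, at 41700 nM, and it also differs elsewhere. A move toward a weaker number in this assay therefore seems more likely than none, though the data leave its size uncertain.

The expected change is a 3.3-fold higher number from compound 2 to compound 3 (0.52 log units; beyond the scatter), modestly beyond the scatter. For compound 3 the estimated value is 6000 nM, with an expected range of 1800 nM to 20000 nM.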

Compound 3, half-maximal inhibitory concentration: 27500 nM
The estimate for compound 3 lay 4.6-fold (0.66 log units) below the measured number; measured number above the stated range.
By their numbers in this assay, from the lowest: compound 2; then compounds 3 and 1 (each within the scatter of the next).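

In this assay, the change from acetyl to propylcarbonyl on a saturated chain carbon bound to a carbonyl carbon now has a direct reading with bromo held constant: a 15-fold higher number from compound 2 to compound 3 (1.18 log units; beyond the scatter). With propylcarbonyl held constant, bromo in place of methyl on an aromatic carbon gives a 1.5-fold lower number from compound 1 to compound 3 (0.18 log units; within the scatter), so this change does not separate the two compounds, and among the single changes shown only the one at the chain moves the number beyond the scatter. No measurement shown here offers an account of why the added ethyl has so large a step.

The compounds shown leave open whether the number rises gradually or abruptly between acetyl and propylcarbonyl, and how a longer chain, an amine or a carboxylic acid at this place would read. Going by these compounds alone, they also leave open whether methyl and bromo would still read alike with acetyl on the chain, since the single pair that compares them carries propylcarbonyl.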